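Nitro for Hydroxy: Expected Cytotoxicity of Compound 3

The compounds below may be only part of what the source reports. "The series", "measured", "known", "first", "only" and "open" are said of these compounds alone.

Compound 1 `O=c1cc(CNCc2ccccc2Cl)oc2ccc(O)c(O)c12` gives in an ADME assay on Huh-7 cells (Homo sapiens) for cytotoxicity (on this read-out higher numbers stand for lower toxicity in this test and lower numbers for higher toxicity in this test), the value > 100000 nM, a limit of the test and not a number.
Compound 2 `O=c1cc(CNCc2ccccc2O)oc2ccc(O)c(O)c12` gives in this assay the value > 100000 nM, likewise a limit.

Among the measured compounds shown here, compound 2 thus stands only at a limit in this assay, and the single measured step reaching it, a step that the two limits leave unreadable from compound 1 to compound 2, cannot be sized because of the limit of > 100000 nM in this assay, at which 2 of the 2 values shown sit. The change to compound 3 `O=c1cc(CNCc2ccccc2[N+](=O)[O-])oc2ccc(O)c(O)c12` is nitro in place of hydroxy on an aromatic carbon. For the measured compounds named here, no measured step bears readably on this change, so the step of a number no higher from compound 2 to compound 3 (the limit leaves the size open) is expected to be none beyond the scatter, most likely ending again at a limit. Compound 3 is estimated at 100000 nM, between 40000 nM and 300000 nM.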

Compound 3, half-maximal cytotoxic concentration: 41300 nM
The estimate for compound 3 lay 2.4-fold (0.38 log units) above the measured number; measured number inside the range.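

Among the compounds shown here, compound 3 is the only one of the three compounds with a number rather than a limit in this assay, which shows that this aromatic position, ortho to a large group, can shift the read-out towards higher toxicity in this test. Nitro in place of hydroxy gives an at least 2.4-fold lower number from compound 2 to compound 3 (0.38 log units; beyond the scatter), and nitro in place of chloro gives an at least 2.4-fold lower number from compound 1 to compound 3 (0.38 log units; beyond the scatter). Both steps give only a minimum size because the other compound in each stands at a limit: the limit of > 100000 nM in this assay, at which 2 of the 3 values shown sit.

Going by these compounds, whether hydroxy and chloro differ from each other stays open. So does whether an amine or a carboxylic acid at this position would also lower the number.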